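This account rests on a few compounds, and the source may have more. Where it says the series, first, only, none or still open, it means among the compounds named here.

Working notes on the series, read in an ADME assay on microsomes from liver (Mus musculus) for metabolic stability, read by LC-MS, using NADPH, with stated times of 10 min and 30 min, tested at 1 uM; on this read-out higher numbers stand for fast clearance and lower numbers for slow clearance. Compound 1 (`COC(=O)C1=C(C)NC(c2nccs2)=NC1(C)c1ccc(S(C)(=O)=O)cc1`) gives 57 mL/min/kg, compound 2 (`COC(=O)C1=C(C)NC(c2nccs2)=NC1(C)c1ccc(C#N)cc1`) gives 75 mL/min/kg, and compound 3 (`COC(=O)C1=C(CN2CCNC(=O)C2)NC(c2nccs2)=NC1(C)c1ccc(F)cc1`) gives 81 mL/min/kg. All three numbers lie within the scatter of one another, so compound 3 is not separated from either of the other two.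

Compound 4 (`COC(=O)C1=C(CN2CC(OC)C2)NC(c2nccs2)=NC1(C)c1ccc(F)cc1`) differs from compound 3 at one place, a saturated chain carbon bound to a double-bonded ring carbon: 3-methoxyazetidin-1-yl in place of 3-oxopiperazin-1-yl on a saturated chain carbon bound to a double-bonded ring carbon.

Among the measured compounds shown here, only one measured step is available, a 1.3-fold higher number from compound 1 to compound 2 (0.12 log units; within the scatter). It stays within the scatter, and it concerns a cyano and a methylsulfonyl group on an aromatic carbon, not this chain carbon. For the measured compounds named here, no measured compound carries 3-methoxyazetidin-1-yl, and no measured pair isolates a change at this place. No step beyond the scatter is therefore expected, and no direction is favoured.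

This estimate amounts to an expected 1.0-fold lower number from compound 3 to compound 4 (0.01 log units; within the scatter). For compound 4 the expected value is 80 mL/min/kg, with an estimated range of 48 mL/min/kg to 125 mL/min/kg.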

Compound 4, clearance: 88 mL/min/kg
Compound 4: middle estimate off by 1.1-fold (0.04 log units), on the low side; measured number inside the range.
By their numbers in this assay, from the lowest: compounds 1, 2, 3 and 4 (each within the scatter of the next).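

In this assay, among the compounds shown here, the only measured pair that isolates a change on this saturated chain carbon bound to a double-bonded ring carbon gives a 1.1-fold higher number from compound 3 to compound 4 (0.04 log units; within the scatter), so this read-out does not separate 3-methoxyazetidin-1-yl from 3-oxopiperazin-1-yl. The two groups differ in ring size, and only 3-oxopiperazin-1-yl carries a hydrogen-bond donor and a double bond outside aromatic rings, yet neither difference comes with a step beyond the scatter in this pair. No available evidence bears on this result.

The compounds shown leave open whether an open-chain amine such as dimethylamino, or a carboxylic acid, at this place would give a step beyond the scatter. Also open, going by these compounds, is whether either ring would read the same with cyano or methylsulfonyl in place of the aromatic fluorine.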